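Swapping the acyl group on compound 3: an expectation

The source may hold more compounds than are shown below. What is called first, only, known or untested is meant among the compounds shown, and "the series" means these compounds.

Compound 1, `CC1=NN(C(=O)c2ccc([N+](=O)[O-])cc2)C(c2ccccc2O)C1`, in a functional assay on MGC-803 cells (Homo sapiens) for cytotoxicity, read by MTT assay, with a stated time of 48 h; on this read-out higher numbers stand for weaker inhibition and lower numbers for stronger inhibition: 50000 nM
Compound 2, `CC(=O)Oc1ccccc1C1CC(C)=NN1C(=O)CCl`: 3010 nM
Compound 3, `Cc1ccc(C(=O)N2N=C(c3cc4ccccc4oc3=O)CC2c2ccccc2)cc1`: 31300 nM

Among these three numbers, compound 3 stands second highest. Its nearest neighbour is compound 1, whose number lies within the scatter of that of compound 3; compound 2 lies far lower, well beyond the scatter. Compound 4, `CC1CCCN(CC(=O)N2N=C(c3cc4ccccc4oc3=O)CC2c2ccccc2)C1`, has not yet been measured. It differs from compound 3 in one place: (3-methylpiperidin-1-yl)methyl in place of 4-methylphenyl on a carbonyl carbon. For the measured compounds named here, no step between two measured compounds isolates this change, so the expectation rests on little. A modest step towards stronger inhibition, a 1.6-fold lower number from compound 3 to compound 4 (0.19 log units; within the scatter), is expected, though it may not exceed the scatter. Compound 4 is estimated at 20000 nM, with a range from 5000 nM to 60000 nM.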

Compound 4, half-maximal inhibitory concentration: "not active" (no number reported)
Compound 4: no number reported; there is nothing to compare the estimate with.
By their numbers in this assay, from the lowest: compound 2; then compounds 3 and 1 (each within the scatter of the next).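

For the compounds shown here, compound 4 is reported as not active in this assay, with no number, so no step from compound 3 can be read. Nothing measured here accounts for this result. The compounds shown leave open how far (3-methylpiperidin-1-yl)methyl in place of 4-methylphenyl changes inhibition.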